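The compounds below may be only part of what the source reports. "The series", "measured", "known", "first", "only" and "open" are said of these compounds alone.

Measured compounds:
- compound 1, `CCN1CCN(c2ccc(Nc3ncc(Cl)c(Nc4ccccc4C)n3)nc2)CC1`, which reaches only the assay limit of > 100000 nM
- compound 2, `COc1ccc(CNc2nc(Nc3ccc(N4CCN(C)CC4)cn3)ncc2Cl)cc1`, with 14900 nM

Among the measured compounds shown here, in a functional assay on MDA-MB-231 cells (Homo sapiens) for inhibition, read by CCK-8 assay, with a stated time of 48 h (on this read-out lower numbers stand for stronger inhibition of growth and higher numbers for weaker inhibition of growth), compound 2 is the only compound with a numerical result. The value of compound 1 is a limit, not a number, and it marks (the limit of > 100000 nM in this assay, at which 1 of the 2 values shown sits). Compound 2 therefore stands alone as the one measurable point among the two.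

Compound 3, `CC(C)c1cccc(Nc2nc(Nc3ccc(N4CCN(C)CC4)cn3)ncc2Cl)c1`, is not yet measured. It differs from compound 2 by 3-isopropylphenyl in place of 4-methoxybenzyl on a nitrogen on an aromatic ring. For the measured compounds named here, compound 1 also carries an aryl group directly on that nitrogen and sits at the limit, so the two known points give only a rough hint of what a direct aryl attachment does here, and no measured step between them exists.

On that basis compound 3 is expected to be weaker than compound 2, with the step from compound 2 to compound 3 estimated as a 2.3-fold higher number from compound 2 to compound 3 (0.37 log units; beyond the scatter), somewhat beyond the usual scatter but uncertain. The estimate for compound 3 in this assay is 35000 nM, with a range from 9000 nM to 150000 nM.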

Compound 3, concentration for 50% growth inhibition: 5590 nM
The estimate for compound 3 lay 6.3-fold (0.80 log units) above the measured number; measured number below the stated range.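

In this assay, among the compounds shown here, replacing (4-methoxybenzyl)amino by (3-isopropylphenyl)amino gives a 2.7-fold lower number from compound 2 to compound 3 (0.43 log units; beyond the scatter), the only readable step at this place, and it shows that an aryl group set directly on this nitrogen can go with a measurable number. The two groups match in heavy atoms and each holds one six-membered aromatic ring of carbon only, so the step combines the loss of the hydrogen-bond acceptor of 4-methoxybenzyl with the move of the ring onto the nitrogen, and nothing here separates these changes. Compound 1 also carries an aryl group directly on that nitrogen, but it differs in more than one place and its value is a limit, not a number, so no step to it can be read: the limit of > 100000 nM in this assay, at which 1 of the 3 values shown sits.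

A 3-isopropylbenzyl or a 4-methoxyphenyl group on this nitrogen would separate the direct attachment from the choice of ring substituent, and the compounds shown leave that question open. Also open, on these data alone, is how an amine or a carboxylic acid on the phenyl ring would read in this assay.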